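A few compounds are considered here, and "the series" means these few. Any claim that something is new, unique, unknown or untested is made for them only; others in the source may bear on it.

Series notes, sodium/hydrogen exchanger set.

Three members of the series have numbers in a functional assay for inhibition of sodium/hydrogen exchanger (Oryctolagus cuniculus); a lower number here means a stronger inhibitor, a higher number a weaker inhibitor. Compound 1 `Cc1cc(C2CCCCC2)c(S(C)(=O)=O)cc1C(=O)N=C(N)N` gives 22 nM and compound 2 `Cc1cc(SC(C)(C)C)c(S(C)(=O)=O)cc1C(=O)N=C(N)N` gives 22 nM, with no change at the digits printed from compound 1 to compound 2 (within the scatter). Compound 3 `Cc1cc(O)c(S(C)(=O)=O)cc1C(=O)N=C(N)N` gives 220 nM, the highest of the three numbers; the steps of a 10-fold higher number from compound 1 to compound 3 (1.00 log units; beyond the scatter) and a 10-fold higher number from compound 2 to compound 3 (1.00 log units; beyond the scatter) set it apart from the other two, beyond the scatter in each case.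

Compound 4 `Cc1cc(Oc2ccccc2)c(S(C)(=O)=O)cc1C(=O)N=C(N)N` has not been measured in this assay. Relative to compound 3 the difference is phenyl in place of hydrogen on an oxygen on an aromatic ring, so the hydroxy of compound 3 becomes phenoxy in compound 4. For the measured compounds named here, no measured pair carries exactly this change. Going by the values given here, the steps that bear on it are those in which hydroxy took the place of cyclohexyl or of (tert-butyl)sulfanyl on the aromatic carbon, a 10-fold higher number from compound 1 to compound 3 (1.00 log units; beyond the scatter) and a 10-fold higher number from compound 2 to compound 3 (1.00 log units; beyond the scatter); both moved the number up by the same amount. Restoring a carbon-rich group at that oxygen is therefore expected to move the number back down, although how far a phenyl on the oxygen tracks cyclohexyl or (tert-butyl)sulfanyl on the carbon is not known from these data.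

For compound 4 the expected step is a 5.5-fold lower number from compound 3 to compound 4 (0.74 log units; beyond the scatter), giving an estimated 40 nM in this assay, with a range from 12 nM to 130 nM.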

Compound 4, half-maximal inhibitory concentration: 10 nM
Compound 4: middle estimate off by 4.0-fold (0.60 log units), on the high side; measured number below the stated range.
By their numbers in this assay, from the lowest: compound 4; then compounds 1 and 2 (each within the scatter of the next); then compound 3.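

The low numbers at this position do not depend on a carbon or sulfur attached to the aromatic ring: in this assay the oxygen of compound 3 stays in place, and phenyl in place of its hydrogen gives a 22-fold lower number from compound 3 to compound 4 (1.34 log units; beyond the scatter) and more than reverses the loss seen on going to hydroxy. Phenoxy is also not just a stand-in for the earlier groups, since a 2.2-fold lower number from compound 2 to compound 4 (0.34 log units; beyond the scatter) and a 2.2-fold lower number from compound 1 to compound 4 (0.34 log units; beyond the scatter) are printed as beyond the scatter, if only narrowly, and compound 4 therefore has the lowest number of the four. No measurement on these compounds accounts for the size of these steps.

The compounds shown leave open whether a methoxy or a cyclohexyloxy group on the same aromatic carbon would give a number nearer that of compound 3 or that of compound 4, so the contribution of the aromatic ring cannot yet be separated from that of simply capping the oxygen. Also open, from the compounds shown here alone, is how a phenylsulfanyl or anilino group at this position, or a fluorine or methoxy group on the phenyl ring, would compare with phenoxy.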